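The source may hold more compounds than are shown below. What is called first, only, known or untested is meant among the compounds shown, and "the series" means these compounds.

Working notes on the series. Compound 1 `COC(C)(C)CCCC(C)C/C=C/C(C)=C/C(=O)OCCC(C)C`, compound 2 `COC(C)(C)CCCC(C)C/C=C/C(C)=C/C(=O)OC1CC1` and compound 3 `COC(C)(C)CCCC(C)C/C=C/C(C)=C/C(=O)SC(C)C` share one core and have all been measured in a physicochemical assay for lipophilicity; a lower number here means a more polar compound, a higher number a more lipophilic compound. In this assay compound 1 gives 7.03, compound 2 gives 5.71 and compound 3 gives 7.19. The steps between them read a number 1.32 log units lower from compound 1 to compound 2 (beyond the scatter), a number 0.16 log units higher from compound 1 to compound 3 (within the scatter) and a number 1.48 log units higher from compound 2 to compound 3 (beyond the scatter). Compound 3 therefore sits with compound 1 within the scatter and stands beyond the scatter above compound 2.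

Compound 4 `COC(C)(C)CCCC(C)C/C=C/C(C)=C/C(=O)CC(C)C` is not yet measured. Its difference from compound 3 is isobutyl in place of isopropylsulfanyl on a carbonyl carbon. The step that bears most on it is a number 0.16 log units higher from compound 1 to compound 3 (within the scatter), a swap of an oxygen-linked group for the sulfur-linked one at the same carbonyl carbon, which stayed within the scatter; the two large steps both involve cyclopropyloxy, which plays no part here. Among the compounds with values here, no measured pair swaps isopropylsulfanyl for isobutyl. For compound 4 the expected step in this assay is a number 0.29 log units lower from compound 3 to compound 4 (within the scatter), small. Compound 4 is estimated at 6.9, between 6.3 and 7.5.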

Compound 4, partition coefficient: 6.02
Beside the measured number, compound 4's estimate is 0.88 log units above it; measured number outside the range, below it.
By their numbers in this assay, from the lowest: compound 2; then compound 4; then compounds 1 and 3 (each within the scatter of the next).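

At the carbonyl carbon, the swap of the oxygen-linked for the sulfur-linked group left the number in this assay within the scatter, but a carbon-linked group does not stay with them: a number 1.17 log units lower from compound 3 to compound 4 (beyond the scatter) and a number 1.01 log units lower from compound 1 to compound 4 (beyond the scatter) are both large, and a number 0.31 log units higher from compound 2 to compound 4 (beyond the scatter) is modest. Isobutyl and isopropylsulfanyl have equal heavy-atom counts and neither has a ring, so the large step from compound 3 to compound 4 comes with an exchange of sulfur for carbon and no difference in those counts. No measurement here accounts for the size of this step.

Going by these compounds, whether an amine on the same carbonyl carbon would stand with compound 4 or with compounds 1 and 3 stays open. So does whether a longer carbon chain there would close the gap from compound 4 to those two.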